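Swapping a Branched Tail for a Straight One

The compounds below may be only part of what the source reports. "The series", "measured", "known", "first", "only" and "open" are said of these compounds alone.

Compound 1 `CC(=O)OC[C@H]1O[C@@H](n2cc(-c3cc(-c4ccc(C(C)(C)C)cc4)no3)c(=O)[nH]c2=O)C[C@@H]1OC(C)=O` gives 53.8% in a functional assay on HCT-15 cells (Homo sapiens) for cytotoxicity, read by sulforhodamine B assay, tested at 10 uM (on this read-out higher numbers stand for more inhibition at the one concentration tested (going by the name of the read-out) and lower numbers for less inhibition), and stands lowest of the three measured compounds. Compound 3 `CCCCCCCCc1cc(-c2cn([C@H]3C[C@H](O)[C@@H](CO)O3)c(=O)[nH]c2=O)on1` gives 88.2% in this assay, and compound 2 `CC(=O)OC[C@H]1O[C@@H](n2cc(-c3cn(Cc4ccc(C(C)(C)C)cc4)nn3)c(=O)[nH]c2=O)C[C@@H]1OC(C)=O` gives 94.2% in this assay; both lie above compound 1 by more than the usual scatter. Compound 4 `CCCCc1ccc(-c2cc(-c3cn([C@H]4C[C@H](OC(C)=O)[C@@H](COC(C)=O)O4)c(=O)[nH]c3=O)on2)cc1` has not yet been measured. It differs from compound 1 in one place: butyl in place of tert-butyl on an aromatic carbon. Going by the values given here, no measured pair carries this exact change, so its effect is not yet known from any measured comparison. A small rise in inhibition is expected, of a size that may still sit within the scatter, and the step expected from this change is a number 6.2 percentage points higher from compound 1 to compound 4 (within the scatter). Compound 4 is estimated at 60%, within a range from 35% to 85%.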

Compound 4, a percentage reported as inhibition, at one concentration (the size of the read-out at that concentration, not a potency): 71.4%
Compound 4: the middle estimate sits 11.4 percentage points below what was measured; the measured number falls inside the stated range.
By their numbers in this assay, from the lowest: compound 1; then compound 4; then compounds 3 and 2 (each within the scatter of the next).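

In this assay, butyl in place of tert-butyl gives a number 17.6 percentage points higher from compound 1 to compound 4 (beyond the scatter) on an otherwise unchanged structure. The two groups hold the same four carbons, so at this spot on the six-membered aromatic ring, how those carbons are joined changes the read-out, not only how many there are. No measurement here explains why this happens.

On these data alone, it remains open whether a hexyl chain or an amine in this place would raise or lower the number. As far as these compounds go, whether the same swap acts alike on compound 2 also remains open.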